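Bicyclic amide replacing oxanyl on the defined-stereochemistry core

The source may report more compounds than this note shows. Statements on the series, on what has been measured and on what is new or still open speak of the compounds shown alone.

Compound 1, `Cc1cc(N2CCC(N3CCCC3C)C2)ccc1NC(=O)C1CCOCC1`: in an assay on CHO cells for displacement of a labelled ligand from histamine receptor H3 (Macaca mulatta) (on this read-out lower numbers stand for stronger inhibition and higher numbers for weaker inhibition), compound 1 gives 6.8 nM.
Compound 2, `Cc1cc(N2CCC(N3CCCC3C)C2)ccc1NC(=O)C1CC2CCC1C2`: in this assay compound 2 gives 19.9 nM.
Compound 3, `Cc1cc(N2CC[C@H](N3CCC[C@@H]3C)C2)ccc1NC(=O)C1CCOCC1`: in this assay compound 3 gives 0.97 nM.

Among the three measured compounds, compound 3 stands lowest; its nearest neighbour is compound 1, and compound 2 lies furthest from it. The drop a 7.0-fold lower number from compound 1 to compound 3 (0.85 log units; beyond the scatter) rests on (the fact that one of compounds 1 and 3 is drawn with a defined configuration and the other without, at the place where they differ).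

Compound 4, `Cc1cc(N2CC[C@H](N3CCC[C@@H]3C)C2)ccc1NC(=O)C1CC2CCC1C2`, is the unmeasured member. It differs from compound 3 only at the amide: a group of 7 heavy atoms (7 carbon; 2 five-membered non-aromatic rings of carbon only) in place of a group of 6 heavy atoms (5 carbon, 1 oxygen; one six-membered non-aromatic ring with 1 hetero atom), on a carbonyl carbon. The same exchange has already been measured once, on the core without defined configuration, where it gave a 2.9-fold higher number from compound 1 to compound 2 (0.47 log units; beyond the scatter). Going by the values given here, that single step is the only evidence bearing on the change from compound 3 to compound 4, and it points to a modest rise in the number, beyond the scatter.

Compound 4 is therefore expected to show a step of about a 2.9-fold higher number from compound 3 to compound 4 (0.46 log units; beyond the scatter). The estimate for compound 4 in this assay is 2.8 nM, with a plausible range from 1.2 nM to 6.5 nM.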

Compound 4, inhibition constant: 0.55 nM
The estimate for compound 4 lay 5.1-fold (0.71 log units) above the measured number; the whole stated range lies above it.
By their numbers in this assay, from the lowest: compounds 4 and 3 (each within the scatter of the next); then compound 1; then compound 2.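

In this assay the exchange of oxan-4-yl for the group with two five-membered carbon rings, on a carbonyl carbon, brings no rise on the core with defined configuration: the step reads a 1.8-fold lower number from compound 3 to compound 4 (0.25 log units; within the scatter) and gives no order between compound 3 and compound 4. The same exchange therefore does not behave alike on the two cores: (the same change on two cores in this assay, a 2.9-fold higher number (0.47 log units; beyond the scatter) from compound 1 to compound 2 and a 1.8-fold lower number (0.25 log units; within the scatter) from compound 3 to compound 4, 5.2-fold (0.71 log units) apart, beyond the scatter of two such steps). With the new group in place, defined configuration goes with a 36-fold lower number from compound 2 to compound 4 (1.56 log units; beyond the scatter) as against a 7.0-fold lower number from compound 1 to compound 3 (0.85 log units; beyond the scatter) with oxan-4-yl, and configuration is all that separates that pair: (the fact that one of compounds 2 and 4 is drawn with a defined configuration and the other without, at the place where they differ).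

The two stereocentres change together in every step shown, so the share of each remains open. Also open, from the compounds shown here alone, is whether a phenyl ring or an isopropyl chain on the carbonyl carbon would keep the number of compound 4 on this core.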